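This account rests on a few compounds, and the source may have more. Where it says the series, first, only, none or still open, it means among the compounds named here.

Within the data shown here, in a physicochemical assay for lipophilicity, at pH 7.4 (on this read-out lower numbers stand for lower lipophilicity and higher numbers for higher lipophilicity), compound 1 `CNC(=O)c1cc(C(=O)NC2CC2)cn(Cc2cccc(OC)c2)c1=O` gives 3, the lowest of the two numbers measured so far. Compound 2 `CNC(=O)c1cc(C(=O)NC2CCC2)cn(Cc2ccccc2)c1=O` gives 3.8 in this assay, a value that stands above that of compound 1 by more than the usual scatter. Compound 3 `CNC(=O)c1cc(C(=O)NC2CC2)cn(Cc2ccc(F)cc2)c1=O` has not yet been measured in this assay. It differs from compound 1 in a single place: 4-fluorophenyl in place of 3-methoxyphenyl on a saturated chain carbon bound to an aromatic nitrogen. Compound 3 keeps the core of compound 1, and the 4-fluorophenyl sits on the saturated chain carbon bound to an aromatic nitrogen where the 3-methoxyphenyl stood. Among the measured compounds shown here, no pair of measured compounds shows this exchange, so the data give no direct guide for it. A small rise is expected, a number 0.30 log units higher from compound 1 to compound 3 (within the scatter), close to the edge of the scatter rather than clearly beyond it. Compound 3 is therefore estimated at 3.3 in this assay, with a range from 2.9 to 3.7.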

Compound 3, distribution coefficient: 3.2
Compound 3: middle estimate off by 0.10 log units, on the high side; measured number inside the range.
By their numbers in this assay, from the lowest: compounds 1 and 3 (each within the scatter of the next); then compound 2.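

On the saturated chain carbon bound to an aromatic nitrogen, putting 4-fluorophenyl in place of 3-methoxyphenyl gives, in this assay, a number 0.20 log units higher from compound 1 to compound 3 (within the scatter), so this read-out does not separate the two groups. Among these compounds, this is the first pair in the set that differs in one place, and it shows that one substituted phenyl, carrying oxygen, can give way to another, carrying fluorine, with a step that stays within the scatter. Nothing available offers a reason for this result.

Compound 2 differs from compound 1 and from compound 3 in more than one place, so the part played by its cyclobutyl amide and by its unsubstituted phenyl cannot be told apart. Going by these compounds, how a carboxylic acid or an amine on the phenyl ring, or a longer chain in place of the single saturated carbon, would read in this assay remains open.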